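A few compounds are considered here, and "the series" means these few. Any claim that something is new, unique, unknown or untested is made for them only; others in the source may bear on it.

Compound 1, `CC1(C2CCCC2)Cc2cc(OCc3ccc(C(=O)O)cc3)c(Cl)c(Cl)c2C1=O`, in an assay on isolated protein for binding affinity to metabotropic glutamate receptor 2 (Homo sapiens) (on this read-out higher numbers stand for an effect only at larger amounts of compound and lower numbers for an effect already at smaller amounts), gives 892 nM.
Compound 2, `CC(=O)NC(=O)c1ccc(COc2cc3c(c(Cl)c2Cl)C(=O)C(C)(C2CCCC2)C3)cc1`, in this assay gives 442 nM.

The two measured compounds share a core and differ only at the end of the benzylic ether: compound 2 carries the acetamido group in place of the hydroxy on the carbonyl carbon of compound 1, and this step, a 2.0-fold lower number from compound 1 to compound 2 (0.30 log units; within the scatter), does not set the two apart. Compound 2 therefore stands next to compound 1 without a clear gap between them.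

Compound 3, `CC1(C2CCCC2)Cc2cc(OCc3ccc(C(=O)NS(C)(=O)=O)cc3)c(Cl)c(Cl)c2C1=O`, has not been measured in this assay. It differs from compound 2 by methylsulfonyl in place of acetyl on an amide-type nitrogen. Among the measured compounds shown here, the only step that bears on it is the one from compound 1 to compound 2, which replaced the hydroxy at that carbonyl carbon with acetamido and stayed within the scatter. Since that change at the same position moved the number little, a further exchange of the acetyl for methylsulfonyl on the amide-type nitrogen is expected to move it little as well, so the estimated step of a 1.1-fold lower number from compound 2 to compound 3 (0.04 log units; within the scatter) is expected to lie within the scatter. Compound 3 is thus expected to give about 400 nM in this assay, within a range from 150 nM to 1200 nM.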

Compound 3, half-maximal effective concentration: 515 nM
Beside the measured number, compound 3's estimate is 1.3-fold (0.11 log units) below it, within the range that was stated.
By their numbers in this assay, from the lowest: compounds 2, 3 and 1 (each within the scatter of the next).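

In this assay, the exchange of acetyl for methylsulfonyl on the amide-type nitrogen gives a 1.2-fold higher number from compound 2 to compound 3 (0.07 log units; within the scatter) and so leaves the two groups indistinguishable at this nitrogen, even though methylsulfonyl brings in sulfur and carries more hydrogen-bond acceptors than acetyl. Set against the hydroxy of compound 1, methanesulfonamido on the carbonyl carbon gives a 1.7-fold lower number from compound 1 to compound 3 (0.24 log units; within the scatter) and is thus the second replacement of that hydroxy, after acetamido, to stay within the scatter, so the position has now accepted three different end groups without a clear separation in this assay. No independent measurement on these compounds accompanies the result, so nothing can be said about what lies behind it.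

Going by these compounds, all three compounds keep the carbonyl carbon, so it remains open whether the number would hold with a tetrazole or a primary amine at that place. On these data alone, it is equally open whether a phenyl or a longer alkyl chain on the sulfonyl group, in place of its methyl, would produce a step beyond the scatter, or whether this end of the molecule tolerates such groups as well.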